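The source may report more compounds than this note shows. Statements on the series, on what has been measured and on what is new or still open speak of the compounds shown alone.

Compound 2 `O=C(O)c1ccc(S(=O)(=O)N2CCC(NS(=O)(=O)c3cc(S(=O)(=O)c4ccccc4)ccc3C(F)(F)F)CC2)cc1` is the more potent of the two measured compounds in an assay on U2OS cells for inhibition of secreted frizzled-related protein 1 (Homo sapiens), read by a luciferase reporter, with a stated time of 18 h (on this read-out lower numbers stand for an effect already at smaller amounts and higher numbers for an effect only at larger amounts of compound), where compound 2 gives 110 nM. For the measured compounds named here, its only measured neighbour is compound 1 `O=C(c1cccc(Cl)c1)N1CCC(NS(=O)(=O)c2cc(S(=O)(=O)c3ccccc3)ccc2C(F)(F)F)CC1`, which in this assay gives 870 nM; the single measured step, a 7.9-fold lower number from compound 1 to compound 2 (0.90 log units; beyond the scatter), came from exchanging the group on the ring amine nitrogen of the shared core and lies beyond the scatter.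

Compound 3 `N#Cc1cccc(S(=O)(=O)N2CCC(NS(=O)(=O)c3cc(S(=O)(=O)c4ccccc4)ccc3C(F)(F)F)CC2)c1` keeps the sulfonyl link to that ring nitrogen and changes only the aryl group on it: 3-cyanophenyl in place of 4-carboxyphenyl on a sulfonyl sulfur. Going by the values given here, no measured step tests this particular exchange; the one step that exists concerns the same position but swapped both the linker and the aryl group, so it tells only that this position can move the number modestly when changed wholesale. A step of no more than modest size is therefore expected, with a slight lean toward a higher number, and compound 3 is estimated at 250 nM, within 80 nM to 800 nM, corresponding to an expected step of a 2.3-fold higher number from compound 2 to compound 3 (0.36 log units; beyond the scatter).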

Compound 3, half-maximal effective concentration: 170 nM
For compound 3 the middle estimate is 1.5-fold (0.17 log units) above the measured one, and the stated range covers the measured number.
By their numbers in this assay, from the lowest: compounds 2 and 3 (each within the scatter of the next); then compound 1.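

In this assay, replacing 4-carboxyphenyl with 3-cyanophenyl on a sulfonyl sulfur gives a 1.5-fold higher number from compound 2 to compound 3 (0.19 log units; within the scatter) and so does not separate the two compounds. The position therefore accepts a group with 0 hydrogen-bond donors in place of one with 1 without a change beyond the scatter, although this pair alters the substituent and its place on the phenyl ring together. The exchange of (3-chlorophenyl)carbonyl for (3-cyanophenyl)sulfonyl on an amine nitrogen in a ring gives a 5.1-fold lower number from compound 1 to compound 3 (0.71 log units; beyond the scatter) and thus joins the earlier step from compound 1 in the same direction, with neither sulfonyl compound going against it, while nothing measured here explains these numbers.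

The compounds shown leave open how much of the gap to compound 1 belongs to the sulfonyl link and how much to the aryl group, a question that a (3-chlorophenyl)sulfonyl group on the same nitrogen would address. Also open, from the compounds shown here alone, is how a 3-carboxyphenyl group, an unsubstituted phenyl group or an aliphatic amine would read on that sulfonyl sulfur.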